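Swapping a nitrile arm for a pyridine on the core

The source may hold more compounds than are shown below. What is called first, only, known or untested is meant among the compounds shown, and "the series" means these compounds.

The measured compounds and their values:
- compound 1, `Cc1cc(C)cc(Cn2c(=O)cc(N)n(CC#N)c2=O)c1`, gives > 100000 nM in an ADME assay on MT4 cells (Homo sapiens) for cytotoxicity, read by MTT assay, with a stated time of 4 days; a higher number here means that more compound is tolerated, a lower number that less compound is tolerated; this value is a limit of the assay, not a number.
- compound 2, `Cc1cc(C)cc(Cn2c(=O)cc(N3CCCC3)n(Cc3ccccc3)c2=O)c1`, gives 31000 nM in this assay.
- compound 3, `Cc1cc(C)cc(Cn2c(=O)cc(N=[N+]=[N-])n(CC#N)c2=O)c1`, gives 60000 nM in this assay.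

Compound 1 therefore stands only at a limit, as the limit of > 100000 nM in this assay, at which 1 of the 3 values shown sits, states, so its true tolerance is not pinned down. Compound 4, `Cc1cc(C)cc(Cn2c(=O)cc(N)n(Cc3ccccn3)c2=O)c1`, differs from compound 1 in one place: pyridin-2-yl in place of cyano on a saturated chain carbon bound to an aromatic nitrogen. Going by the values given here, the only measured step, an at least 1.6-fold lower number from compound 1 to compound 3 (0.22 log units; that floor lies within the scatter), concerns the amino group and not this arm, so it says little about the change at hand. Compound 2, which carries a benzyl arm together with a pyrrolidinyl group, shows a lower value than the limit of compound 1, but its difference lies in two places. With the pyridin-2-yl arm, compound 4 is expected to remain near the upper end, giving an estimated 80000 nM within 30000 nM to 200000 nM. The expected step is an at least 1.2-fold lower number from compound 1 to compound 4 (0.09 log units; that floor lies within the scatter).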

Compound 4, half-maximal cytotoxic concentration: > 100000 nM
Compound 4: no number, only a limit (the forecaster's own chance of this, stated with the estimate: 40%); at least 1.2-fold (0.09 log units) between middle value and limit.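

Compound 1 and compound 4 each stand only at a limit in this assay, so no step between them can be read: the limit of > 100000 nM in this assay, at which 2 of the 4 values shown sit.

The compounds shown leave open how much of either compound is truly tolerated, and whether pyridin-2-yl in place of cyano changes that at all.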